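Hydroxy to amino at the limit of the assay

A few compounds are considered here, and "the series" means these few. Any claim that something is new, unique, unknown or untested is made for them only; others in the source may bear on it.

Compound 1 is `Cn1c(/C=C/C(=O)c2ccccc2)cc(Br)c1Br`, compound 2 is `Cn1c(/C=C/C(=O)c2cccc(O)c2)cc(Br)c1Br` and compound 3 is `Cn1c(/C=C/C(=O)c2cc(O)ccc2O)cc(Br)c1Br`. They share one core and differ only in hydroxy groups on an aromatic ring. In a functional assay on KB403 cells (Homo sapiens) for cytotoxicity, read by MTT assay, with stated times of 6 h and 48 h (on this read-out higher numbers stand for weaker inhibition and lower numbers for stronger inhibition), compound 1 gives >= 100000 nM, which is a limit and not a number. Compound 2 gives >= 100000 nM, also only a limit. Compound 3 gives >= 100000 nM, again a limit. The whole record so far is the limit of >= 100000 nM in this assay, at which 3 of the 3 values shown sit.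

Compound 4, `Cn1c(/C=C/C(=O)c2cccc(N)c2)cc(Br)c1Br`, has not yet been measured. It carries amino in place of hydroxy on an aromatic carbon of compound 2, meta to a large group: amino in place of hydroxy on an aromatic carbon.

The two changes already measured, a step that the two limits leave unreadable from compound 1 to compound 2 and a step that the two limits leave unreadable from compound 2 to compound 3, give no size to carry over, so no step beyond the scatter is expected in this assay. The expected outcome is a number no higher from compound 2 to compound 4 (the limit leaves the size open). For compound 4 the estimate is 100000 nM, with an expected range from 30000 nM to 200000 nM.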

Compound 4, half-maximal inhibitory concentration: >= 100000 nM
Compound 4: only a limit was reported (the forecaster's own chance of this, stated with the estimate: 75%); the middle value lies on the limit itself.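

No step can be read among compound 1, compound 2, compound 3 and compound 4, since each value is a limit and not a number: the limit of >= 100000 nM in this assay, at which 4 of the 4 values shown sit. The compounds shown leave open how strongly any of them inhibits, and whether any of these changes on the aromatic ring alters that.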